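A fluorophenyl for an iodophenyl: what to expect

The source may hold more compounds than are shown below. What is called first, only, known or untested is meant among the compounds shown, and "the series" means these compounds.

Compound 1 `N#Cc1ccc(OCC2CCN(CCCF)CC2)cc1`: in an assay for binding affinity to Sigma non-opioid intracellular receptor 1 (Rattus norvegicus) (a higher number here means a weaker inhibitor, a lower number a stronger inhibitor), compound 1 gives 4.3 nM.
Compound 2 `FCCCN1CCC(COc2c(F)c(F)c(F)c(F)c2F)CC1`: in this assay compound 2 gives 1.7 nM.
Compound 3 `N#Cc1ccc(OCC2CCN(Cc3ccccc3I)CC2)cc1`: in this assay compound 3 gives 9.24 nM.

Compound 3 stands at the highest number of the three, meaning the weakest binding among them. Going by the values given here, its nearest neighbour is compound 1, and the only single-point step in the set links them: a 2.1-fold higher number from compound 1 to compound 3 (0.33 log units; beyond the scatter). Compound 2 sits further away, with the lowest number of the three.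

The unmeasured compound 4 `N#Cc1ccc(OCC2CCN(Cc3ccc(F)cc3)CC2)cc1` differs from compound 3 in one place: 4-fluorophenyl in place of 2-iodophenyl on a saturated chain carbon bound to an amine nitrogen in a ring. Among the compounds with values here, the group stays an aromatic ring on the same carbon, so the only step that bears on it is the one from compound 1 to compound 3, which was modest. Nothing in the set compares two different aromatic rings at this position, so the direction is uncertain; the expected step of a 1.8-fold lower number from compound 3 to compound 4 (0.27 log units; within the scatter) is small, most likely within the scatter or slightly toward a lower number. For compound 4 the estimate in this assay is 5 nM, with a range from 1.5 nM to 15 nM.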

Compound 4, inhibition constant in the Sigma non-opioid intracellular receptor 1 assay: 0.76 nM
For compound 4 the middle estimate is 6.6-fold (0.82 log units) above the measured one, and the stated range ends above it.
By their numbers in the Sigma non-opioid intracellular receptor 1 assay, from the lowest: compound 4; then compound 2; then compound 1; then compound 3.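

Going by these compounds alone, in the Sigma non-opioid intracellular receptor 1 assay, the group on this carbon turns out to matter much more than the earlier compounds suggested: replacing 2-iodobenzyl with 4-fluorobenzyl gives a 12-fold lower number from compound 3 to compound 4 (1.08 log units; beyond the scatter), whereas the one earlier step at this position was modest. The aromatic ring is therefore not a drawback in itself, since the 4-fluorophenyl group also improves on the 2-fluoroethyl group, with a 5.7-fold lower number from compound 1 to compound 4 (0.75 log units; beyond the scatter). In a physicochemical assay for lipophilicity (on this read-out higher numbers stand for higher lipophilicity and lower numbers for lower lipophilicity), compound 3 gives 4.3 and compound 4 gives 3.22. The change from compound 3 to compound 4 also comes with lower lipophilicity in the physicochemical assay: the measured partition coefficient of compound 3, 4.3, and of compound 4, 3.22, a number 1.08 log units lower (beyond the scatter)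

Both the halogen and its place on the ring differ in this step, and the compounds shown cannot tell those two changes apart. Also open, going by these compounds, is whether a plain benzyl group, with no halogen, or a pyridine ring would bind as strongly.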